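Fluoropyridyl for fluorophenyl across two chalcone cores

The compounds below may be only part of what the source reports. "The series", "measured", "known", "first", "only" and "open" are said of these compounds alone.

Two cores are compared in a functional assay on SW480 cells (Homo sapiens) for antiproliferative activity, read by sulforhodamine B assay, with a stated time of 48 h; on this read-out higher numbers stand for weaker inhibition and lower numbers for stronger inhibition. Compound 1, `COc1ccc(/C=C/C(=O)c2ccccc2-c2ccc(F)cc2)cc1OC`, gives 570 nM, and compound 2, `COc1ccc(/C=C/C(=O)c2ccccc2-c2ccc(F)nc2)cc1OC`, gives 1300 nM. The change 6-fluoropyridin-3-yl in place of 4-fluorophenyl on an aromatic carbon gives a 2.3-fold higher number from compound 1 to compound 2 (0.36 log units; beyond the scatter). Compound 3, `COc1ccc(C(=O)/C=C/c2ccccc2-c2ccc(F)cc2)cc1`, gives 8400 nM, the highest number of the three; its difference from the core of compound 1 is not broken down here. Compound 4, `COc1ccc(C(=O)/C=C/c2ccccc2-c2ccc(F)nc2)cc1`, carries the change (6-fluoropyridin-3-yl in place of 4-fluorophenyl on an aromatic carbon); the place is described in the same words for both pairs, so this is taken as the same change on a second core. Among the compounds with values here, nothing is known of how the change behaves on the core of compound 3, and the only anchor is the step from compound 1 to compound 2. From compound 3 to compound 4 a step of a 2.3-fold higher number from compound 3 to compound 4 (0.35 log units; beyond the scatter) is expected in this assay, matching the earlier step because a 2.3-fold higher number from compound 1 to compound 2 (0.36 log units; beyond the scatter) was modest but beyond the scatter. Compound 4 is therefore estimated at 19000 nM, with a range of 8000 nM to 45000 nM.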

Compound 4, half-maximal inhibitory concentration: 10000 nM
Estimate against measurement, compound 4: 1.9-fold (0.28 log units) above; the measured number falls inside the stated range.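

On the core of compound 3, 6-fluoropyridin-3-yl in place of 4-fluorophenyl gives a 1.2-fold higher number from compound 3 to compound 4 (0.08 log units; within the scatter) in this assay, so the two compounds cannot be told apart on this read-out. Set beside the step on the core of compound 1, this result does not differ from it by more than repeat measurements allow, and the change carries from one core to the other as far as these two pairs can show: the same change on two cores in this assay, a 2.3-fold higher number (0.36 log units; beyond the scatter) from compound 1 to compound 2 and a 1.2-fold higher number (0.08 log units; within the scatter) from compound 3 to compound 4, 1.9-fold (0.28 log units) apart, within the scatter of two such steps. Within the data shown here, two pairs in a single assay do not fix a size for the change, nor do they settle whether it carries a real cost on either core, as only the step on the core of compound 1 lies beyond the scatter.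

Open, on these data alone, is whether the same holds for an amine or a methoxy group in place of the fluorine of the 6-fluoropyridin-3-yl group. Also open, as far as these compounds go, is how the change behaves on any core other than these two.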